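Hydroxy for chloro on the pyrazoline aryl: paw edema series

This account rests on a few compounds, and the source may have more. Where it says the series, first, only, none or still open, it means among the compounds named here.

Measured so far in a functional assay on the whole organism (strain Wistar albino) for inhibition, with Rattus norvegicus as the target, read by paw edema, with stated times of 30 min and 3 h, at a dose of 0.05 mmol/kg; on this read-out lower numbers stand for less inhibition and higher numbers for more inhibition at the one dose given (going by the name of the read-out):
compound 1 `NS(=O)(=O)c1ccc(N2N=C(c3cccc(O)c3)C[C@H]2c2ccccc2)cc1` gives 35.8%;
compound 2 `NS(=O)(=O)c1ccc(N2N=C(c3cccc(O)c3)C[C@H]2c2ccc(Cl)cc2)cc1` gives 19.2%;
compound 3 `COc1ccc([C@@H]2CC(c3cccc(O)c3)=NN2c2ccc(S(N)(=O)=O)cc2)cc1` gives 64.7%.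

Compound 2 stands lowest of the three: a number 16.6 percentage points lower from compound 1 to compound 2 (beyond the scatter) and a number 45.5 percentage points higher from compound 2 to compound 3 (beyond the scatter), both beyond the scatter. Compound 4 `NS(=O)(=O)c1ccc(N2N=C(c3cccc(O)c3)C[C@H]2c2ccc(O)cc2)cc1` differs from compound 2 by hydroxy in place of chloro on an aromatic carbon, on the aromatic carbon para to a large group.

For the measured compounds named here, two steps bear on it. Removing the chloro for hydrogen gave the reverse of a number 16.6 percentage points lower from compound 1 to compound 2 (beyond the scatter); exchanging it for methoxy gave a number 45.5 percentage points higher from compound 2 to compound 3 (beyond the scatter). Both directions point upward from compound 2, and hydroxy enters with one donor and one acceptor, so a step upward in this assay is expected, estimated as a number 30.8 percentage points higher from compound 2 to compound 4 (beyond the scatter).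

Compound 4 is therefore expected to give about 50%, within 30% to 70%.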

Compound 4, a percentage reported as inhibition, in the whole organism at one dose (the size of the read-out at that dose, not a potency): 64.7%
For compound 4 the middle estimate is 14.7 percentage points below the measured one; low and high end bracket the measured number.
By their numbers in this assay, from the lowest: compound 2; then compound 1; then compounds 3 and 4 (each within the scatter of the next).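

In this assay, hydroxy in place of chloro at this position gives a number 45.5 percentage points higher from compound 2 to compound 4 (beyond the scatter), and hydroxy in place of hydrogen gives a number 28.9 percentage points higher from compound 1 to compound 4 (beyond the scatter). Hydrogen in place of methyl on the oxygen gives no change at the digits printed from compound 3 to compound 4 (within the scatter), so the hydroxy and methoxy groups are not separated at this dose. Nothing measured here gives a cause for these steps.

On these data alone, whether an oxygen on the ring is required remains open, and an amine or a longer ether such as ethoxy at the same place would test this. A single dose also leaves compound 3 and compound 4 unresolved in potency.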